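Methyl for fluoro on a pyrazole-linked aryl: cytotoxicity expectation

A few compounds are considered here, and "the series" means these few. Any claim that something is new, unique, unknown or untested is made for them only; others in the source may bear on it.

Of the compounds shown here, two from this series have been tested in an ADME assay on HEK-293T cells (Homo sapiens) for cytotoxicity, read by MTT assay, with a stated time of 24 h; a higher number here means that more compound is tolerated, a lower number that less compound is tolerated. Compound 1 `Cc1ccc(-c2nn(-c3ccccc3)cc2-c2nc3ccccc3n2C(=O)c2ccccc2C)cc1` gives 176000 nM in this assay. Compound 2 `O=C(c1cccnc1)n1c(-c2cn(-c3ccccc3)nc2-c2ccc(F)cc2)nc2ccccc21` gives 216000 nM in this assay. These two numbers lie within the usual scatter of each other, so compound 2 stands level with compound 1; neither can be called better tolerated on these data.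

Compound 3 `Cc1ccc(-c2nn(-c3ccccc3)cc2-c2nc3ccccc3n2C(=O)c2cccnc2)cc1` has not yet been tested. It differs from compound 2 in one place: methyl in place of fluoro on an aromatic carbon. The same methyl group is already present in compound 1, whose number in this assay sits close to that of compound 2, so the step from compound 2 to compound 3 is expected to be small, a 1.1-fold lower number from compound 2 to compound 3 (0.04 log units; within the scatter), with no direction beyond the scatter. Compound 3 is therefore estimated to give about 195000 nM in this assay, with a likely range from 100000 nM to 380000 nM.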

Compound 3, half-maximal cytotoxic concentration: 189000 nM
The estimate for compound 3 lay 1.0-fold (0.01 log units) above the measured number; the measured number falls inside the stated range.
By their numbers in this assay, from the lowest: compounds 1, 3 and 2 (each within the scatter of the next).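

In this assay the swap from 4-fluorophenyl to 4-methylphenyl can now be read on its own as a 1.1-fold lower number from compound 2 to compound 3 (0.06 log units; within the scatter) and so does not separate the two groups at this position. Among these compounds, compound 3 also gives the first single-place comparison at the carbonyl carbon, where pyridin-3-yl in place of 2-methylphenyl is a 1.1-fold higher number from compound 1 to compound 3 (0.03 log units; within the scatter) and likewise separates nothing. No measurement at hand offers a cause for either result.

On these data alone, whether an amine, a carboxylic acid or a longer chain on this aromatic carbon would move the number beyond the scatter remains open. As far as these compounds go, it is equally open whether either of these two results would hold with a different group at the other place, since each swap has been read against one background only.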